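The compounds below may be only part of what the source reports. "The series", "measured", "known", "first", "only" and "open" are said of these compounds alone.

Compound 1 `CC1=CC[C@H](C(C)C)c2cc(C)c(OC(=O)c3ccc(C)cc3)cc21` carries a 4-methylphenyl group on its ester carbonyl carbon. In a functional assay on SK-LU-1 cells (Homo sapiens) for antiproliferative activity, read by sulforhodamine B assay, with a stated time of 48 h, tested at 50 uM (a lower number here means less inhibition, a higher number more inhibition at the concentration tested (going by the name of the read-out)), compound 1 gives 85.4%, the highest of the two numbers reported. Compound 2 `Cc1cc2c(C(C)C)ccc(C)c2cc1OC(=O)c1cccc(C(F)(F)F)c1`, built on a different core and bearing a trifluoromethyl group on its aromatic ester ring, gives 17.3%, far below compound 1. Compound 3 `CC1=CC[C@H](C(C)C)c2cc(C)c(OC(=O)c3ccc(C(F)(F)F)cc3)cc21` shares the core of compound 1 and also bears a trifluoromethyl group on the ester ring; for compound 3 the result was reported as "not active" (no number reported), with no number.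

Compound 4 `CC1=CC[C@H](C(C)C)c2cc(C)c(OC(=O)c3cccc(Cl)c3)cc21` has not been measured yet. It differs from compound 1 in a single place: 3-chlorophenyl in place of 4-methylphenyl on a carbonyl carbon. Going by the values given here, no pair of measured compounds differs in only one place, so the size of the step cannot be read from a measured comparison. Compound 3 shows that altering that ring can remove activity, while compound 1 shows the methyl version inhibits strongly. I therefore expect a step downward beyond the scatter, a number 40.4 percentage points lower from compound 1 to compound 4 (beyond the scatter). Compound 4 is expected to give 45%, in a range from 10% to 85%.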

Compound 4, a percentage reported as inhibition, at one concentration (the size of the read-out at that concentration, not a potency): 30.6%
Estimate against measurement, compound 4: 14.4 percentage points above; the range from low to high includes it.
By their numbers in this assay, from the lowest: compound 2; then compound 4; then compound 1.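

Putting 3-chlorophenyl in place of 4-methylphenyl on the carbonyl carbon gives a number 54.8 percentage points lower from compound 1 to compound 4 (beyond the scatter) in this assay, the first measured size for a change at this position with the core held the same. The two groups count the same heavy atoms and each is a single six-membered aromatic ring of carbon, so the ester ring's substituent can change the number greatly even when these counts stay the same, and compound 4 still gives a number at 30.6% where compound 3 has none. Nothing measured here explains the fall.

This change swaps the substituent and moves it on the ring at once, so the two effects cannot be told apart. Compounds with 4-chlorophenyl or 3-methylphenyl would separate them, and a ring carrying an amine or a carboxylic acid remains unexplored among the compounds shown.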